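The source may hold more compounds than are shown below. What is called first, only, known or untested is meant among the compounds shown, and "the series" means these compounds.

Compound 1 `N#Cc1ccc(-c2nc(NCCNc3ccc([N+](=O)[O-])c(N)n3)ncc2-c2ncc[nH]2)cc1`: > 0.5 h
Compound 2 `Nc1nc(NCCNc2ncc(-c3ncc[nH]3)c(-c3ccc(F)cc3F)n2)ccc1[N+](=O)[O-]`: > 0.5 h
Compound 3 `Nc1nc(NCCNc2ncc(-c3ncc[nH]3)c(-c3cc(F)ccc3F)n2)ccc1[N+](=O)[O-]`: > 0.5 h

In an ADME assay on microsomes from liver (Rattus norvegicus) for metabolic stability (on this read-out lower numbers stand for a shorter-lived compound and higher numbers for a longer-lived compound), compound 3 gives > 0.5 h, which is a limit of the assay and not a number. It is not alone in this: the limit of > 0.5 h in this assay, at which 3 of the 3 values shown sit. Compound 4 `Nc1nc(NCCNc2ncc(-c3ncc[nH]3)c(-c3ccc(Cl)cc3F)n2)ccc1[N+](=O)[O-]` keeps the shared core and swaps one group: 4-chloro-2-fluorophenyl in place of 2,5-difluorophenyl on an aromatic carbon. The nearest comparison is a step that the two limits leave unreadable from compound 2 to compound 3, and next to it stand a step that the two limits leave unreadable from compound 1 to compound 2 and a step that the two limits leave unreadable from compound 1 to compound 3, so none of these changes of the same group has a readable size. With only compound 3 at > 0.5 h to go on, the expected step that the limit leaves unreadable from compound 3 to compound 4 is nothing beyond the scatter, in either direction. Compound 4 will most likely report the same limit, and as a number it is estimated at 0.7 h, within 0.5 h to 1.5 h.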

Compound 4, half-life: > 0.5 h
Compound 4 gave a limit, no number (the forecaster's own chance of this, stated with the estimate: 85%); the middle value is on the limit's open side.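

For the compounds shown here, compound 4 also gives a limit and not a number, so no step linking compound 1, compound 2, compound 3 and compound 4 can be read in this assay: the limit of > 0.5 h in this assay, at which 4 of the 4 values shown sit. As far as these compounds go, how long each of these four compounds actually lasts, and whether their groups change that, stays open.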